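Carboxy to sulfomethyl on the amide chain: expected efficacy

The source may report more compounds than this note shows. Statements on the series, on what has been measured and on what is new or still open speak of the compounds shown alone.

compound 1 `O=C(O)CNC(=O)c1ccc(C2CC2c2ccc(OCc3c(-c4c(Cl)cccc4Cl)noc3C3CC3)cc2Cl)cc1` 58%
compound 2 `O=C(O)c1ccc(C2CC2c2ccc(OCc3c(-c4c(Cl)cccc4Cl)noc3C3CC3)cc2Cl)cn1` 68%
compound 3 `O=C(NCCS(=O)(=O)O)c1ccc(C2CC2c2ccc(OCc3c(-c4c(Cl)cccc4Cl)noc3C3CC3)cc2Cl)cc1` not yet measured

In an assay on HEK293 cells for agonist activity at Bile acid receptor (Homo sapiens) (a lower number here means a smaller maximal response, a higher number a larger maximal response), compound 1 gives 58% and compound 2 gives 68%. Compound 1 holds the lower of the two numbers, yet its gap to compound 2 lies within the scatter, so the pair is not separated. For the measured compounds named here, no one-place step between measured compounds exists in this set. Compound 3 differs from compound 1 by sulfomethyl in place of carboxy on a saturated chain carbon bound to an amide-type nitrogen. With nothing comparable measured, the change is expected to shift the maximal response little, if at all, beyond the scatter. The expected step is a number 2 percentage points higher from compound 1 to compound 3 (within the scatter). Compound 3 is estimated at 60%, within 40% to 80%.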

Compound 3, largest response reached (reported as efficacy), in percent of the reference or control that the assay uses: 34%
Estimate against measurement, compound 3: 26 percentage points above; the whole stated range lies above it.
By their numbers in this assay, from the lowest: compound 3; then compounds 1 and 2 (each within the scatter of the next).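

In this assay, for the compounds shown here, sulfomethyl in place of carboxy on a saturated chain carbon bound to an amide-type nitrogen gives a number 24 percentage points lower from compound 1 to compound 3 (beyond the scatter) and provides the first step that exceeds the scatter. The maximal response is therefore sensitive to the group carried on this amide chain. Nothing available explains the step.

Carboxymethyl to 2-sulfoethyl alters both the end group and the chain, leaving their separate contributions unresolved. A 2-carboxyethyl group on the same amide nitrogen would separate them, while a phosphonic acid would test another end group.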